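This account rests on a few compounds, and the source may have more. Where it says the series, first, only, none or still open, it means among the compounds named here.

Of the compounds shown here, two sharing one core have been measured in a functional assay on IGROV-1 cells (Homo sapiens) for cytotoxicity, read by sulforhodamine B assay, with a stated time of 48 h, tested at 0.001 uM; on this read-out lower numbers stand for a stronger effect and higher numbers for a weaker effect at the one concentration tested. Compound 1 is `Cc1cc(O)cc(-c2nn(CC#N)cc2-c2ccnc(-c3ccc(Oc4ccccc4)cc3)c2)c1`; in this assay compound 1 gives 98%. Compound 2 is `COc1cc(C)cc(-c2nn(CC#N)cc2-c2ccnc(-c3ccc(N(C)C)cc3)c2)c1`; in this assay compound 2 gives 103%. Compound 2 stands at the top of these two numbers, yet its gap to compound 1 lies within the usual scatter, so the two readings count as the same result: at this very low concentration neither compound does anything measurable to the cells.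

Compound 3 is `Cc1cc(O)cc(-c2nn(CC#N)cc2-c2ccnc(-c3ccc(N(C)C)cc3)c2)c1` and has not been measured yet. It differs from compound 2 by hydrogen in place of methyl on an oxygen on an aromatic ring. Going by the values given here, no measured pair shows this change on its own, so its size has to be estimated from what the two measured compounds show. Because compound 1 gives 98% while already carrying the hydroxy group, the step is expected to be a number 3 percentage points lower from compound 2 to compound 3 (within the scatter), which means no change beyond the scatter. Compound 3 is therefore expected to give 100%, with a likely range from 90% to 110%.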

Compound 3, a percentage reported as activity, at one concentration (the size of the read-out at that concentration, not a potency): 107%
Estimate against measurement, compound 3: 7 percentage points below, within the range that was stated.
By their numbers in this assay, from the lowest: compounds 1, 2 and 3 (each within the scatter of the next).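

Going by these compounds alone, with methoxy to hydroxy as the only difference on the aromatic ring, this assay gives a number 4 percentage points higher from compound 2 to compound 3 (within the scatter) and so offers the first direct look at this swap, which leaves the cells reading the same at the single very low concentration tested. The hydroxy compounds also provide a second single-place comparison, with dimethylamino in place of phenoxy giving a number 9 percentage points higher from compound 1 to compound 3 (within the scatter) and again no difference that can be told from the scatter, so neither position separates the compounds under these conditions. No measurement is available to explain these readings, and a flat result at one low concentration cannot show whether either group matters for cytotoxicity.

Going by these compounds, it remains open whether a longer chain such as ethoxy, or an amine, on that aromatic ring would read differently from methoxy and hydroxy, and whether a carboxylic acid in place of dimethylamino would move the number. With all three compounds showing no measurable effect on the cells, these readings also leave open how the same groups would compare at a concentration where the cells respond.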